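A benzyloxy group added to compound 2

A few compounds are considered here, and "the series" means these few. Any claim that something is new, unique, unknown or untested is made for them only; others in the source may bear on it.

Of the compounds shown here, three sharing a core have been read in a functional assay on ileum (Cavia porcellus) for antagonist activity, with a stated time of 30 s (on this read-out lower numbers stand for stronger inhibition and higher numbers for weaker inhibition), and they lie close together. Compound 1 (`O=C(O)c1cc(=O)c2ccc(OCCCOc3ccccc3)cc2o1`) gives 1.4 ug/mL while compound 2 (`O=C(O)c1cc(=O)c2ccc(OCCCCCOc3ccccc3)cc2o1`) gives 0.4 ug/mL and compound 3 (`O=C(O)c1cc(=O)c2ccc(OCCCCCc3ccccc3)cc2o1`) gives 0.6 ug/mL on the same read-out. The spread is told by a 3.5-fold lower number from compound 1 to compound 2 (0.54 log units; beyond the scatter) and by a 2.3-fold lower number from compound 1 to compound 3 (0.37 log units; beyond the scatter) while a 1.5-fold higher number from compound 2 to compound 3 (0.18 log units; within the scatter) remains a difference that cannot be read as real. Compound 2 therefore shares the low end of this small set with compound 3.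

Compound 4 (`O=C(O)c1cc(=O)c2ccc(OCCCCCOc3cccc(OCc4ccccc4)c3)cc2o1`) departs from compound 2 by benzyloxy in place of hydrogen on an aromatic carbon with benzyloxy in place of hydrogen on an aromatic carbon. All three measured steps concern the chain, and none of them puts a new group on an aromatic ring, so they offer only a rough guide to size. The largest of them is a 3.5-fold lower number from compound 1 to compound 2 (0.54 log units; beyond the scatter) and it is modest. They give no direction for the new group, and no step beyond the scatter is expected in this assay on this evidence. The estimated step is a 1.3-fold higher number from compound 2 to compound 4 (0.10 log units; within the scatter) with a wide margin on either side. For compound 4 the estimate is 0.5 ug/mL within an expected range of 0.12 ug/mL to 2 ug/mL on this read-out.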

Compound 4, half-maximal inhibitory concentration: 1 ug/mL
Beside the measured number, compound 4's estimate is 2.0-fold (0.30 log units) below it; the range from low to high includes it.
By their numbers in this assay, from the lowest: compounds 2, 3, 4 and 1 (each within the scatter of the next, the first and the last beyond it).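

Going by these compounds alone, this is the first change on the outer aromatic ring rather than in the chain, and in this assay it gives a 2.5-fold higher number from compound 2 to compound 4 (0.40 log units; beyond the scatter), a modest loss of inhibition that lies beyond the scatter. An aromatic carbon of this ring, meta to a large group, therefore accepts benzyloxy, with its 8 heavy atoms and a second six-membered aromatic ring, while the read-out stays in the same general range, so this single pair shows that the position responds to substitution but does not abolish activity. Nothing at hand accounts for the direction or size of this shift.

On these data alone, a single substituent at a single carbon cannot separate the contribution of the position from that of the group, so it remains open whether methoxy, chlorine or a small amine on the same aromatic carbon would also raise the number, or whether benzyloxy would behave the same way on another carbon of that ring. As far as these compounds go, it is equally open whether the same benzyloxy change would give a step of similar size on the shorter chain of compound 1.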